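From Methyl Ester to Free Acid on the Shared Core

The source may report more compounds than this note shows. Statements on the series, on what has been measured and on what is new or still open speak of the compounds shown alone.

For the measured compounds named here, compound 3 `COC(=O)/C=C/c1ccncc1-c1ccc2ccccc2c1` is the one member of this small set that gives an actual number in a functional assay on KB cells (Homo sapiens) for inhibition, read by sulforhodamine B assay, with a stated time of 72 h; a lower number here means a stronger inhibitor of growth, a higher number a weaker inhibitor of growth: compound 3 gives 6730 nM. Its two neighbours sit at the limit of the assay. Compound 1 `CNC(=O)CCc1ccncc1-c1ccc2ccccc2c1` gives only the limit > 10000 nM in this assay. Compound 2 `O=C(O)CCc1ccncc1-c1ccc2ccccc2c1` likewise gives only the limit > 10000 nM in this assay. the limit of > 10000 nM in this assay, at which 2 of the 3 values shown sit, therefore leaves the step that the two limits leave unreadable from compound 1 to compound 2 unreadable, while the steps of an at least 1.4-fold lower number from compound 1 to compound 3 (0.17 log units; that floor lies within the scatter) and an at least 1.4-fold lower number from compound 2 to compound 3 (0.17 log units; that floor lies within the scatter) each have only a floor, and that floor lies within the scatter.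

Compound 4 `O=C(O)/C=C/c1ccncc1-c1ccc2ccccc2c1` differs from compound 3 by hydrogen in place of methyl on an oxygen next to a carbonyl group, that is, methoxycarbonyl becomes carboxy. The nearest measured guide is compound 2, a carboxy compound that reaches only the limit, set against compound 3, whose ester gives a number; the step of an at least 1.4-fold lower number from compound 2 to compound 3 (0.17 log units; that floor lies within the scatter) runs in the ester's favour. The move from ester to acid in compound 4 is therefore expected to raise the number in this assay, most likely back to the limit. For compound 4 the expected value is 15000 nM, between 5000 nM and 50000 nM, a step of a 2.2-fold higher number from compound 3 to compound 4 (0.35 log units; beyond the scatter) that is estimated rather than measured.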

Compound 4, concentration for 50% growth inhibition: > 10000 nM
Compound 4 ended at the assay's limit; the forecaster's own chance of this, stated with the estimate: 60%; the middle value lies beyond the limit too.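

In this assay, hydrogen in place of methyl on an oxygen next to a carbonyl group gives an at least 1.4-fold higher number from compound 3 to compound 4 (0.17 log units; that floor lies within the scatter). For the compounds shown here, this is the first view of methoxycarbonyl against carboxy with nothing else changed, as compound 2, the earlier carboxy compound, also carries a 2-carboxyethyl chain rather than the 2-carboxyethenyl chain of compound 4. Even so, the result fixes only a direction that stays inside the scatter, and the steps joining compound 4 to compound 1 and to compound 2 cannot be read because each pair has a limit at both ends: the limit of > 10000 nM in this assay, at which 3 of the 4 values shown sit.

As far as these compounds go, the true size of the change from methoxycarbonyl to carboxy stays open, as does whether the number for compound 3 depends on the methoxycarbonyl group, on the ethenyl chain, or on the two together. A compound carrying 2-(methoxycarbonyl)ethyl, or one carrying 2-(ethoxycarbonyl)ethenyl, would help to separate these possibilities.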